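Formyl to methoxycarbonyl on a pyrrole-free core: expected gain

A few compounds are considered here, and "the series" means these few. Any claim that something is new, unique, unknown or untested is made for them only; others in the source may bear on it.

Measured compounds:
Compound 1 `Cc1c(C(=O)OC(C)(C)C)c[nH]c1C(=O)OC(C)(C)C` — 100 nM
Compound 2 `CCCOC(=O)c1[nH]c(C=O)c(C(=O)OC(C)(C)C)c1C` — 2000 nM

In an assay on CHO cells for inhibition of metabotropic glutamate receptor 1 (Rattus norvegicus) (a lower number here means a stronger inhibitor, a higher number a weaker inhibitor), compound 1 gives 100 nM. In this assay compound 2 gives 2000 nM, the highest of the two numbers, and its nearest neighbour is compound 1, with a gap between them that lies beyond the scatter. Within the data shown here, no step between the two measured compounds that differ in a single place is known.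

Compound 3 `CCCOC(=O)c1[nH]c(C(=O)OC)c(C(=O)OC(C)(C)C)c1C` follows from compound 2 by one change: methoxy in place of hydrogen on a carbonyl carbon, which, cut one bond further out, reads formyl to methoxycarbonyl. Because compound 1, which carries an ester rather than an aldehyde at that place, gives 100 nM, a move in the same direction is expected, but of modest size: the step of a 2.5-fold lower number from compound 2 to compound 3 (0.40 log units; beyond the scatter) is estimated to be a decrease that may or may not exceed the scatter. Compound 3 is therefore expected to give about 800 nM, within 200 nM to 3000 nM.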

Compound 3, half-maximal inhibitory concentration: 3200 nM
Beside the measured number, compound 3's estimate is 4.0-fold (0.60 log units) below it; measured number outside the range, above it.
By their numbers in this assay, from the lowest: compound 1; then compounds 2 and 3 (each within the scatter of the next).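

In this assay, among these compounds, methoxy in place of hydrogen on a carbonyl carbon, read one bond further out as formyl to methoxycarbonyl, gives a 1.6-fold higher number from compound 2 to compound 3 (0.20 log units; within the scatter), the first comparison here between compounds that differ in one place. At this position, therefore, the assay does not separate the two groups, even though methoxy adds two heavy atoms and one hydrogen-bond acceptor. No measurement shown explains why the two groups read alike.

On these data alone, it remains open whether a carboxylic acid, a primary amide or a longer ester chain on this carbonyl carbon would shift the number beyond the scatter. Also open, as far as these compounds go, is whether a single change to the propyl ester that compound 2 and compound 3 share, such as an amide in its place, would do so.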